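Trading Methoxy for Fluoro in a Growth Inhibitor

A few compounds are considered here, and "the series" means these few. Any claim that something is new, unique, unknown or untested is made for them only; others in the source may bear on it.

Three measured compounds share one core and differ only in the groups on their aromatic rings. In a functional assay on MCF7 cells (Homo sapiens) for inhibition, with a stated time of 48 h, tested at 50 uM (a lower number here means less inhibition of growth, a higher number more inhibition of growth at the concentration tested), compound 2 `COc1ccc(/C=C/[C@@](C)(/C=C/c2ccc(O)cc2)CCC=C(C)C)cc1` gives 55%, the highest number of the three. Where compound 2 carries 4-methoxyphenyl, compound 1 `COc1ccccc1/C=C/[C@@](C)(/C=C/c1ccc(O)cc1)CCC=C(C)C` carries 2-methoxyphenyl and gives 42%. Compound 3 `CC(C)=CCCC(C)(/C=C/c1ccc(O)cc1)/C=C/c1ccc(O)cc1` has hydrogen in place of methyl on that oxygen and gives 31%.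

The unmeasured compound 4 `CC(C)=CCC[C@](C)(/C=C/c1ccc(O)cc1)/C=C/c1ccc(F)cc1` keeps the rest of compound 2 but turns 4-methoxyphenyl into 4-fluorophenyl: fluoro in place of methoxy on an aromatic carbon. For the measured compounds named here, two measured steps bear on this change, and both are modest but beyond the scatter. The closer guide is the change made at the same methoxy group, a number 24 percentage points lower from compound 2 to compound 3 (beyond the scatter). The other, a number 13 percentage points higher from compound 1 to compound 2 (beyond the scatter), shows that the number also responds when the methoxy group sits elsewhere on the ring. Going by the values given here, no measured compound carries fluoro, so neither step predicts this swap directly. A modest drop is expected, smaller than the step at the methoxy group and possibly within the scatter. The estimated change is a number 10 percentage points lower from compound 2 to compound 4 (within the scatter). For compound 4 the expected value is 45%, with a likely range from 30% to 60%.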

Compound 4, percent growth inhibition at one concentration: 28%
Beside the measured number, compound 4's estimate is 17 percentage points above it, and the stated range ends above it.
By their numbers in this assay, from the lowest: compounds 4 and 3 (each within the scatter of the next); then compound 1; then compound 2.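

Swapping methoxy for fluoro on this aromatic carbon gives a number 27 percentage points lower from compound 2 to compound 4 (beyond the scatter) in this assay, so a second replacement at this position, after the hydroxyl of compound 3, also falls short of compound 2. Here compound 3 gives 31% and compound 4 gives 28%, values within the usual scatter of each other, so these two groups cannot be told apart in this read-out. The 4-fluorophenyl compound also falls short of the 2-methoxyphenyl compound, with a number 14 percentage points lower from compound 1 to compound 4 (beyond the scatter), which shows that methoxy keeps a higher number than fluoro at the para carbon even when it is compared from another place on the ring.

Nothing shown here explains why the number falls with this change. On these data alone, whether an amine, a chlorine atom or a longer ethoxy group on this carbon would bring the number back towards that of compound 2 stays open, and so does how these compounds would compare at concentrations other than the single one tested.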